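The source may report more compounds than this note shows. Statements on the series, on what has been measured and on what is new or still open speak of the compounds shown alone.

Measured in a functional assay on MCF7 cells (Homo sapiens) for cytotoxicity, read by CellTiter-Glo, with a stated time of 5 days; on this read-out higher numbers stand for weaker inhibition and lower numbers for stronger inhibition:
- compound 1 `C/C(=C(/c1ccc(/C=C/C(=O)O)cc1)c1ccc2[nH]ncc2c1)c1ccccc1`: 40 nM
- compound 2 `O=C(O)/C=C/c1ccc(/C(=C(/CCO)c2ccccc2)c2ccc3[nH]ncc3c2)cc1`: > 1000 nM

Compound 2 stands at a limit of the assay, not at a number: > 1000 nM. Compound 3 `O=C(O)/C=C/c1ccc(/C(=C(\c2ccccc2)C(F)F)c2ccc3[nH]ncc3c2)cc1` carries difluoromethyl in place of 2-hydroxyethyl on a double-bonded chain carbon bound to an aromatic carbon and a double-bonded chain carbon. Going by the values given here, the one measured step bearing on this is an at least 25-fold higher number from compound 1 to compound 2 (1.39 log units; beyond the scatter), which added hydroxymethyl on a saturated chain carbon bound to a double-bonded chain carbon. With the 2-hydroxyethyl gone from compound 3, a large move to a lower number is expected in this assay, though not necessarily all the way back to the value of compound 1. The estimated step is an at least 10-fold lower number from compound 2 to compound 3 (1.00 log units; beyond the scatter). For compound 3 the expected value is 100 nM, with an estimated range from 20 nM to 600 nM.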

Compound 3, half-maximal inhibitory concentration: 14 nM
The estimate for compound 3 lay 7.1-fold (0.85 log units) above the measured number; the measured number lies below the stated range.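

In this assay, this position on a double-bonded chain carbon bound to an aromatic carbon and a double-bonded chain carbon can do better than methyl: difluoromethyl in place of methyl gives a 2.9-fold lower number from compound 1 to compound 3 (0.46 log units; beyond the scatter). Difluoromethyl in place of 2-hydroxyethyl gives an at least 71-fold lower number from compound 2 to compound 3 (1.85 log units; beyond the scatter), so the earlier loss is fully recovered and passed. For compound 2 the value is a limit of the assay, not a number: the limit of > 1000 nM in this assay, at which 1 of the 3 values shown sits.

The compounds shown leave open whether ethyl or trifluoromethyl would sit nearer compound 1 or compound 3. They also leave open whether the hydroxyl or the chain of 2-hydroxyethyl carries the loss.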